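Methoxy Substitution on the Core of Compound 1

The compounds below may be only part of what the source reports. "The series", "measured", "known", "first", "only" and "open" are said of these compounds alone.

Measured so far:
compound 1 `c1ccc2c(C3CC(c4ccncc4)=NO3)c[nH]c2c1`: 12800 nM
compound 2 `Cc1c(C2CC(c3ccncc3)=NO2)c2ccccc2n1Cc1ccc(Cl)cc1`: 2500 nM

In a functional assay on LNCaP C4-2 cells (Homo sapiens) for inhibition, read by MTT assay, with a stated time of 48 h (a lower number here means a stronger inhibitor, a higher number a weaker inhibitor), compound 1 gives 12800 nM, the highest of the two numbers. Compound 2 gives 2500 nM, a lower number, and the gap between these two lies beyond the scatter. Compound 3 `COc1ccc2c(C3CC(c4ccncc4)=NO3)c[nH]c2c1` has not yet been measured. It differs from compound 1 by methoxy in place of hydrogen on an aromatic carbon. Going by the values given here, no pair of measured compounds isolates such a change, so its size cannot be read from the numbers at hand. The step of a 1.3-fold lower number from compound 1 to compound 3 (0.11 log units; within the scatter) is expected to stay within the scatter, with no clear direction. Compound 3 is estimated at 10000 nM, in the range 4000 nM to 30000 nM.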

Compound 3, half-maximal inhibitory concentration: 3500 nM
Beside the measured number, compound 3's estimate is 2.9-fold (0.46 log units) above it; the whole stated range lies above it.
By their numbers in this assay, from the lowest: compounds 2 and 3 (each within the scatter of the next); then compound 1.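

In this assay, methoxy in place of hydrogen on an aromatic carbon brings a 3.7-fold lower number from compound 1 to compound 3 (0.56 log units; beyond the scatter), a modest step and the first single-place change measured in the series. This place on the six-membered aromatic ring of the shared core therefore responds to substitution, and methoxy there lowers the number. Nothing measured bears on what lies behind the step.

Still open, from the compounds shown here alone, is whether a hydroxyl, a fluorine or a longer chain such as ethoxy at this place would give a similar number. Also open, going by these compounds, is how methoxy would act on the other aromatic carbons of that ring.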